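Benzyl in Place of tert-Butyl on the Ester Oxygen

The compounds below may be only part of what the source reports. "The series", "measured", "known", "first", "only" and "open" are said of these compounds alone.

Of the compounds shown here, three sharing one core have been measured. Compound 1 `CC1=C(C(=O)OCc2ccccc2)C(c2ccco2)NC(=O)N1` gives 36% in an assay on membranes from CHO cells for displacement of a labelled ligand from adenosine receptor A1 (Homo sapiens), read by scintillation counting, with a stated time of 60 min, tested at 1 uM; a lower number here means less inhibition, a higher number more inhibition at the concentration tested (going by the name of the read-out). Compound 2 `CCCOC(=O)C1=C(C)NC(=O)NC1c1ccoc1` gives 50% in this assay, and compound 3 `CC1=C(C(=O)OC(C)(C)C)C(c2ccoc2)NC(=O)N1` gives 11% in this assay, the lowest of the three numbers, with compound 1 the nearest to it and compound 2 the furthest.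

Among the measured compounds shown here, the one measured step at the ester oxygen, a number 39 percentage points lower from compound 2 to compound 3 (beyond the scatter), ran in the downward direction. Compound 4 `CC1=C(C(=O)OCc2ccccc2)C(c2ccoc2)NC(=O)N1` differs from compound 3 by benzyl in place of tert-butyl on an oxygen next to a carbonyl group, so the change reverses that route and replaces the tert-butyl group with a benzyl group. For the measured compounds named here, no step from tert-butyl to benzyl on this core has been measured; the only guide is that compound 1, which carries a benzyl group on a core that differs elsewhere, gives 36%, between the values of compound 2 and compound 3.

Compound 4 is therefore expected to rise beyond the scatter, by roughly a number 29 percentage points higher from compound 3 to compound 4 (beyond the scatter). The estimate for compound 4 is 40%, with a range from 20% to 60%.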

Compound 4, a percentage reported as inhibition, at one concentration (the size of the read-out at that concentration, not a potency): 41%
Compound 4: the middle estimate sits 1 percentage points below what was measured; measured number inside the range.
By their numbers in this assay, from the lowest: compound 3; then compounds 1, 4 and 2 (each within the scatter of the next, the first and the last beyond it).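

In this assay benzyl in place of tert-butyl on an oxygen next to a carbonyl group gives a number 30 percentage points higher from compound 3 to compound 4 (beyond the scatter) and so shows that this oxygen can carry a ring-bearing group without the loss seen with tert-butyl. Phenyl in place of ethyl on a saturated chain carbon bound to that oxygen gives a number 9 percentage points lower from compound 2 to compound 4 (within the scatter) and so, of the three groups compared on the furan-3-yl compounds, only tert-butyl stands apart. Furan-3-yl in place of furan-2-yl on a saturated ring carbon gives a number 5 percentage points higher from compound 1 to compound 4 (within the scatter) and so this swap shows no separable change with benzyl on the ester oxygen.

The compounds shown leave open how an isopropyl group, a methyl group or a longer chain on this oxygen would compare, and whether an amine on the benzyl ring would leave the number higher, lower or level. Nothing available here accounts for why tert-butyl stands apart.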